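Replacing a 3-Methoxyphenyl Group in a Series Level in the Read-out

A few compounds are considered here, and "the series" means these few. Any claim that something is new, unique, unknown or untested is made for them only; others in the source may bear on it.

Measured compounds:
Compound 1 `CC(C)(C)Cc1csc(N)c1C(=O)c1ccc(Cl)cc1`: in an assay on CHO cells for displacement of a labelled ligand from adenosine receptor A1 (Homo sapiens), read by scintillation counting, tested at 10 uM (a higher number here means more inhibition at the concentration tested (going by the name of the read-out), a lower number less inhibition), compound 1 gives 1%.
Compound 2 `CC(C)(C)Cc1c(/C=C/c2ccc(Cl)cc2)sc(N)c1C(=O)c1ccc(Cl)cc1`: in this assay compound 2 gives 1%.
Compound 3 `COc1cccc(-c2sc(N)c(C(=O)c3ccc(Cl)cc3)c2CC(C)(C)C)c1`: in this assay compound 3 gives 1%.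

Compound 3 stands level with compounds 1 and 2 at the digits reported; its nearest neighbour in this assay is compound 1 and its furthest is compound 2, yet neither gap leaves the scatter. The three steps among the measured compounds, no change at the digits printed from compound 1 to compound 3 (within the scatter), no change at the digits printed from compound 2 to compound 3 (within the scatter) and no change at the digits printed from compound 1 to compound 2 (within the scatter), all vary the same aromatic carbon and none moves the read-out beyond the scatter.

Compound 4 `CC(C)(C)Cc1c(-c2ccsc2)sc(N)c1C(=O)c1ccc(Cl)cc1` is not yet measured. It differs from compound 3 as follows: thiophen-3-yl in place of 3-methoxyphenyl on an aromatic carbon

For the measured compounds named here, the steps that bear on this change are those that exchanged groups at this same carbon, no change at the digits printed from compound 1 to compound 3 (within the scatter) and no change at the digits printed from compound 2 to compound 3 (within the scatter), both flat. Compound 4 is therefore expected to show a number 1 percentage points higher from compound 3 to compound 4 (within the scatter), a step of no size beyond the scatter in this assay. Compound 4 is estimated to give 2%, with a range from -8% to 12%.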

Compound 4, a percentage reported as inhibition, at one concentration (the size of the read-out at that concentration, not a potency): 2%
The estimate for compound 4 equals the measured number at the digits printed; the measured number falls inside the stated range.
By their numbers in this assay, from the lowest: compounds 1, 2, 3 and 4 (each within the scatter of the next).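

In this assay, thiophen-3-yl on this carbon next to the ring sulfur reads like the larger 3-methoxyphenyl, with a number 1 percentage points higher from compound 3 to compound 4 (within the scatter). The same holds against the 2-(4-chlorophenyl)ethenyl group, with a number 1 percentage points higher from compound 2 to compound 4 (within the scatter), and against hydrogen, with a number 1 percentage points higher from compound 1 to compound 4 (within the scatter). A five-membered aromatic ring with a sulfur atom, the first such group shown at this carbon, thus stays level with the six-membered ring, the styryl-type chain and the bare carbon, and nothing available explains this flatness.

On these data alone, whether a carboxylic acid or an aminomethyl group on this carbon would shift the read-out remains open. So does whether replacing the neopentyl group or the (4-chlorophenyl)carbonyl group, which all four compounds share, would move the number at all.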